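The source may report more compounds than this note shows. Statements on the series, on what has been measured and on what is new or still open speak of the compounds shown alone.

Series notes. Compound 1 `Cc1cccc(C#Cc2ccc(C(=O)N[C@H](C)C(C)(C)O)nc2)c1` gives 68.6% in a functional assay on HEK293 cells for positive allosteric modulation of metabotropic glutamate receptor 5 (Rattus norvegicus), read by fluorescence and calcium flux; on this read-out lower numbers stand for smaller maximal responses and higher numbers for larger maximal responses. Compound 2 `Cc1nc(C#Cc2ccc(C(=O)N[C@H](C)C(C)(C)O)nc2)cs1` gives 66.6% in this assay. Compound 3 `C[C@@H](NC(=O)c1ccc(C#CC2CC2)cn1)C(C)(C)O` gives 63.4% in this assay, the lowest of the three numbers shown, though each gap to it lies within the scatter: a number 5.2 percentage points lower from compound 1 to compound 3 (within the scatter) and a number 3.2 percentage points lower from compound 2 to compound 3 (within the scatter). Compound 4 `C[C@@H](NC(=O)c1ccc(C#CC2CCCC2)cn1)C(C)(C)O` has not yet been measured. Its difference from compound 3 is cyclopentyl in place of cyclopropyl on a triple-bonded carbon. Within the data shown here, the steps that bear on this position, a number 2 percentage points lower from compound 1 to compound 2 (within the scatter), a number 5.2 percentage points lower from compound 1 to compound 3 (within the scatter) and a number 3.2 percentage points lower from compound 2 to compound 3 (within the scatter), all exchange the group on the triple-bonded carbon and all stay within the scatter, so no step beyond the scatter is expected in this assay for the cyclopentyl group either. Compound 4 is therefore estimated at 65%, with a range of 54% to 76%. The expected step is a number 1.6 percentage points higher from compound 3 to compound 4 (within the scatter).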

Compound 4, largest response reached (reported as efficacy), in percent of the reference or control that the assay uses: 63.7%
Estimate against measurement, compound 4: 1.3 percentage points above; measured number inside the range.
By their numbers in this assay, from the lowest: compounds 3, 4, 2 and 1 (each within the scatter of the next).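

In this assay, cyclopentyl on the triple-bonded carbon cannot be told apart from cyclopropyl (a number 0.3 percentage points higher from compound 3 to compound 4 (within the scatter)), so these two rings of carbon only are not separated by this read-out. Cyclopentyl also stays within the scatter of the 2-methyl-1,3-thiazol-4-yl group (a number 2.9 percentage points lower from compound 2 to compound 4 (within the scatter)) and the 3-methylphenyl group (a number 4.9 percentage points lower from compound 1 to compound 4 (within the scatter)). No measured evidence bears on this result.

As far as these compounds go, whether an amine, a hydroxyl or a longer open carbon chain on the triple-bonded carbon would move the response beyond the scatter in this assay remains open.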